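The source may report more compounds than this note shows. Statements on the series, on what has been measured and on what is new or still open speak of the compounds shown alone.

Within the data shown here, the three compounds measured so far share one core and differ mainly in the group attached to it. Compound 2 `Cn1ccc2cc(-c3ccc4oc(Nc5ccccc5)nc4c3)ccc21` carries an anilino group, and in an assay on HEK293 cells for inhibition of Fatty-acid amide hydrolase 1 (Homo sapiens), read by fluorescence (on this read-out higher numbers stand for weaker inhibition and lower numbers for stronger inhibition), compound 2 gives 48 nM. Compound 3 `Cn1ccc2cc(-c3ccc4oc(Cc5ccccc5)nc4c3)ccc21` carries a benzyl group in its place; in this assay compound 3 gives 488 nM, the highest number of the three, and the step of a 10-fold higher number from compound 2 to compound 3 (1.01 log units; beyond the scatter) shows how far the number rose. Compound 1 `NC(=O)Cn1ccc2cc(-c3ccc4oc(NC5CCCCC5)nc4c3)ccc21` carries a cyclohexylamino group and differs from the others elsewhere as well; in this assay compound 1 gives 214 nM, which sits between the other two.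

Compound 4 `COc1ccc(Nc2nc3cc(-c4ccc5c(ccn5C)c4)ccc3o2)cc1` has not yet been measured. It differs from compound 3 in one place: (4-methoxyphenyl)amino in place of benzyl on an aromatic carbon. Among the measured compounds shown here, this change largely reverses the one step on record, because the step of a 10-fold higher number from compound 2 to compound 3 (1.01 log units; beyond the scatter) ran from the anilino compound to the benzyl compound, and compound 4 returns to an anilino group that now also carries a methoxy group. For the measured compounds named here, no measured pair shows what that methoxy group alone does. The expectation is therefore a large move back toward a lower number, about a 9.8-fold lower number from compound 3 to compound 4 (0.99 log units; beyond the scatter). Compound 4 is estimated to give 50 nM in this assay, with a likely range from 18 nM to 150 nM.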

Compound 4, half-maximal inhibitory concentration: 280 nM
Compound 4: middle estimate off by 5.6-fold (0.75 log units), on the low side; measured number outside the range, above it.
By their numbers in this assay, from the lowest: compound 2; then compounds 1, 4 and 3 (each within the scatter of the next, the first and the last beyond it).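

The step of a 1.7-fold lower number from compound 3 to compound 4 (0.24 log units; within the scatter) lies within the scatter, so in this assay this (4-methoxyphenyl)amino group and the benzyl group it replaces cannot be told apart at this position on the five-membered ring. The step that isolates the methoxy group, methoxy in place of hydrogen on an aromatic carbon, is a 5.8-fold higher number from compound 2 to compound 4 (0.77 log units; beyond the scatter) and lies beyond the scatter, so the low number of the plain anilino compound does not carry over to every anilino group and a single added group can remove most of that advantage over benzyl. This is the first sign that the outcome at this position depends on more than the atom linking the group to the core, though nothing shown here gives a measured reason for the methoxy effect.

As far as these compounds go, it remains open whether this rise belongs to methoxy itself or would also follow from a different group in its place, such as a fluorine atom, a hydroxyl group or a methyl group. A single substituted anilino compound also cannot show whether a carboxylic acid or an amine on that group would bring the number back down.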